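The source may report more compounds than this note shows. Statements on the series, on what has been measured and on what is new or still open speak of the compounds shown alone.

Among the measured compounds shown here, compound 2 `Cc1cc(-c2nc3n(c2/C=N/NC(=N)N)CCS3)c(C)s1` stands lowest of the two numbers so far in a functional assay on cells (Cancer cell lines, Homo sapiens) for inhibition (on this read-out lower numbers stand for stronger inhibition of growth and higher numbers for weaker inhibition of growth), where compound 2 gives 18600 nM; its nearest neighbour is compound 1 `N=C(N)N/N=C/c1c(-c2ccsc2)nc2n1CCS2`, which in this assay gives 25100 nM, and the step of a 1.3-fold lower number from compound 1 to compound 2 (0.13 log units; within the scatter) lies within the scatter. Compound 3 `N=C(N)N/N=C/c1c(-c2cccs2)nc2n1CCS2` differs from compound 2 by thiophen-2-yl in place of 2,5-dimethylthiophen-3-yl on an aromatic carbon. For the measured compounds named here, the only step that bears on this, a 1.3-fold lower number from compound 1 to compound 2 (0.13 log units; within the scatter), also swapped one thiophene for another without moving the number beyond the scatter, so no step beyond the scatter is expected here either, in either direction. The expected step for compound 3 is a 1.2-fold higher number from compound 2 to compound 3 (0.07 log units; within the scatter). Compound 3 is therefore estimated at 22000 nM, with a range from 9000 nM to 55000 nM.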

Compound 3, concentration for 50% growth inhibition: 19100 nM
Compound 3: the middle estimate sits 1.2-fold (0.06 log units) above what was measured; low and high end bracket the measured number.
By their numbers in this assay, from the lowest: compounds 2, 3 and 1 (each within the scatter of the next).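

Working notes on the thiophene at this aromatic carbon, in this assay: thiophen-2-yl in place of thiophen-3-yl gives a 1.3-fold lower number from compound 1 to compound 3 (0.12 log units; within the scatter), so the change of thiophene attachment point also stays within the scatter. Thiophen-2-yl in place of 2,5-dimethylthiophen-3-yl gives a 1.0-fold higher number from compound 2 to compound 3 (0.01 log units; within the scatter), so the three thiophene groups cannot be told apart on this read-out. No supporting evidence bears on this result.

Still open, going by these compounds, is whether a group other than a thiophene at this aromatic carbon, such as phenyl, an amine or a carboxylic acid, would give a step beyond the scatter.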